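The source may report more compounds than this note shows. Statements on the series, on what has been measured and on what is new or still open speak of the compounds shown alone.

Compound 1 `COc1cccc(/C=N/c2ccc(OCc3ccccc3)cc2)c1O` gives in a functional assay, with a stated time of 30 min (on this read-out higher numbers stand for weaker inhibition and lower numbers for stronger inhibition), only a limit of the assay, > 200000 nM.
Compound 2 `Oc1cccc(/C=N/c2ccc(OCc3ccccc3)cc2)c1O` gives in this assay 13300 nM.
Compound 3 `Cc1ccc(/C=N/c2ccc(OCc3ccccc3)cc2)c(O)c1` gives in this assay only a limit of the assay, > 200000 nM.

Compound 3 thus stands at the limit shared by two of the three compounds, (the limit of > 200000 nM in this assay, at which 2 of the 3 values shown sit), and only compound 2 has a measured number. The change to compound 4 `Oc1ccccc1/C=N/c1ccc(OCc2ccccc2)cc1` is hydrogen in place of methyl on an aromatic carbon. Of the measured steps, an at least 15-fold lower number from compound 1 to compound 2 (1.17 log units; beyond the scatter) concerns an oxygen and not a ring carbon, so it does not bear on this change. Among the compounds with values here, the step of an at least 15-fold higher number from compound 2 to compound 3 (1.17 log units; beyond the scatter) exchanges the whole ring, and in it the methyl enters together with the loss of one hydroxy group; it bears on the present step only in part, and no measured step isolates the methyl alone. The expected step in this assay for compound 4 is therefore small and of uncertain direction, an at least 1.3-fold lower number from compound 3 to compound 4 (0.12 log units; that floor lies within the scatter). Compound 4 is estimated at 150000 nM, within 30000 nM to 400000 nM, with a fair chance that the assay again reports only a limit.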

Compound 4, half-maximal inhibitory concentration: > 200000 nM
Compound 4 ended at the assay's limit (the forecaster's own chance of this, stated with the estimate: 60%); middle value at least 1.3-fold (0.12 log units) from the limit.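

In this assay, the loss of a hydroxy group alone gives an at least 15-fold higher number from compound 2 to compound 4 (1.17 log units; beyond the scatter), whereas an at least 15-fold higher number from compound 2 to compound 3 (1.17 log units; beyond the scatter) also brought in a methyl. The loss of the measurable value therefore appears with the hydroxy change alone, and the methyl of compound 3 is not required for the read-out to reach the limit. The steps from compound 3 to compound 4 and from compound 1 to compound 4 cannot be read, as both ends of each are limits: the limit of > 200000 nM in this assay, at which 3 of the 4 values shown sit.

Within the data shown here, what the methyl does on its own remains open, as no pair with a measured value at both ends isolates it. Also open, on these data alone, is whether an amine or a carboxylic acid in place of that hydroxy would keep a measured value, as compound 2 does with 13300 nM.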